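Clearance of three pyrrole-linked esters in mouse liver microsomes

The source may hold more compounds than are shown below. What is called first, only, known or untested is meant among the compounds shown, and "the series" means these compounds.

Measured so far:
- compound 1, `CCOC(=O)C1=C(C)N/C(=C/c2cc(C)n(-c3ccc(Cl)cc3)c2C)C1=O`, gives 72 mL.min-1.g-1 in an ADME assay on microsomes from liver (Mus musculus) for metabolic stability, read by LC-MS, tested at 1 uM; a lower number here means slower removal, a higher number faster removal of the compound
- compound 2, `CCOC(=O)C1=C(C)N/C(=C/c2cc(C)n(-c3ccc(SC)cc3)c2C)C1=O`, gives 66 mL.min-1.g-1 in this assay

Compound 2 carries a methylsulfanyl group on the aromatic ring that hangs from the shared core, and its number in this assay is the lowest of the two measured. It sits close to compound 1, the one with chloro in the same place: the change from chloro to methylsulfanyl gave a 1.1-fold lower number from compound 1 to compound 2 (0.04 log units; within the scatter), so the two compounds cannot be told apart on this read-out.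

Compound 3, `CCOC(=O)C1=C(C)N/C(=C/c2cc(C)n(-c3ccc(CN4CCCCC4)cc3)c2C)C1=O`, is not yet measured. Its difference from compound 2 is (piperidin-1-yl)methyl in place of methylsulfanyl on an aromatic carbon. Within the data shown here, the only measured step, from compound 1 to compound 2, swaps one small group for another on this same aromatic carbon and moves nothing beyond the scatter; it bears on compound 3 only in showing that the last swap at this place left the clearance where it was. Among the measured compounds shown here, a larger group now enters, and no measured pair shows what such a group does here, so the expectation rests on the unchanged core. Compound 3 is therefore expected to stay near the measured pair, with a step of a 1.1-fold higher number from compound 2 to compound 3 (0.03 log units; within the scatter) that lies within the scatter. The estimate for compound 3 is 70 mL.min-1.g-1, with a range from 35 mL.min-1.g-1 to 140 mL.min-1.g-1.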

Compound 3, intrinsic clearance in microsomes: 60 mL.min-1.g-1
The estimate for compound 3 lay 1.2-fold (0.07 log units) above the measured number, within the range that was stated.
By their numbers in this assay, from the lowest: compounds 3, 2 and 1 (each within the scatter of the next).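

Among these compounds, until now, the only swap at this aromatic carbon, para to a large group, had been between two small groups. Compound 3 shows that a much larger group, (piperidin-1-yl)methyl with its six-membered non-aromatic ring, can stand at this place without taking the number in this assay beyond the scatter: putting it in place of methylsulfanyl gave a 1.1-fold lower number from compound 2 to compound 3 (0.04 log units; within the scatter) and putting it in place of chloro gave a 1.2-fold lower number from compound 1 to compound 3 (0.08 log units; within the scatter) so the three compounds cannot be told apart on this read-out, even with groups this different in size. Nothing measured here speaks to what lies behind this flat result.

On these data alone, what a carboxylic acid, a primary amide or a longer chain ending in an amine would do at this aromatic carbon remains open. Also open, as far as these compounds go, is whether a change elsewhere on the shared core, such as an amide in place of the ethyl ester, would move the number in this assay beyond the scatter.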